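A Methyl for Phenyl Swap Among Three Limit Values

The source may hold more compounds than are shown below. What is called first, only, known or untested is meant among the compounds shown, and "the series" means these compounds.

Compound 1 `CS(=O)(=O)c1ccc(C(=O)NCCCC(=O)N2CCC(c3ccccc3)CC2)cc1[N+](=O)[O-]`: in an assay on isolated protein for inhibition of thyroid hormone receptor beta (Homo sapiens), read by fluorescence polarization (a lower number here means a stronger inhibitor, a higher number a weaker inhibitor), compound 1 gives > 60000 nM, a limit of the assay.
Compound 2 `CCCN(C(=O)CN(C)C(=O)c1ccc(S(C)(=O)=O)c([N+](=O)[O-])c1)c1ccccc1`: in this assay compound 2 gives > 60000 nM, also a limit.
Compound 3 `CC(C)N(C(=O)C1CCN(C(=O)c2ccc(S(C)(=O)=O)c([N+](=O)[O-])c2)CC1)C(C)C`: in this assay compound 3 gives > 60000 nM, again a limit.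

Compound 1 thus stands where all three measured compounds stand, at the limit of > 60000 nM in this assay, at which 3 of the 3 values shown sit; no number separates it from the others, and no pair of these compounds differs in one place, so no measured step exists. Compound 4 `CC1CCN(C(=O)CCCNC(=O)c2ccc(S(C)(=O)=O)c([N+](=O)[O-])c2)CC1` differs from compound 1 by methyl in place of phenyl on a saturated ring carbon. With every measured value a limit, no direction can be read, and compound 4 is expected to sit at the limit as well, estimated at 100000 nM, between 30000 nM and 300000 nM. The expected step in this assay a step that the limit leaves unreadable from compound 1 to compound 4 is therefore no more than the scatter.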

Compound 4, half-maximal inhibitory concentration: > 60000 nM
Compound 4 ended at the assay's limit (the forecaster's own chance of this, stated with the estimate: 90%); the middle value does not contradict the limit.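

Among these compounds, compound 1 and compound 4 both stand at a limit of the assay, and no step between them can be read. The compounds shown leave open what difference, if any, phenyl and methyl make in this assay and which structures would give a value inside the assay's range.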